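A few compounds are considered here, and "the series" means these few. Any claim that something is new, unique, unknown or untested is made for them only; others in the source may bear on it.

Compound 1 `O=C(NS(=O)(=O)c1ccc(F)cc1)c1ccc(Nc2nc(NC3(c4ccc(Cl)cc4)CC3)nc(OCC(F)(F)F)n2)cc1`: 99%
Compound 2 `CC(C)S(=O)(=O)NC(=O)c1ccc(Nc2nc(NC3(c4ccc(Cl)cc4)CC3)nc(OCC(F)(F)F)n2)cc1`: 96%
Compound 3 `CC(C)(C)CNCCS(=O)(=O)NC(=O)c1ccc(Nc2nc(NC3(c4ccc(Cl)cc4)CC3)nc(OCC(F)(F)F)n2)cc1`: 90%

In an ADME assay on microsomes from liver (Rattus norvegicus) for metabolic stability, with a stated time of 10 min (a lower number here means that less of the compound is left, a higher number that more of the compound is left), compound 1 has the highest of the three numbers, but the gaps to the others lie within the scatter: a number 3 percentage points lower from compound 1 to compound 2 (within the scatter) and a number 9 percentage points lower from compound 1 to compound 3 (within the scatter). Compound 4 `CC(=O)NCCS(=O)(=O)NC(=O)c1ccc(Nc2nc(NC3(c4ccc(Cl)cc4)CC3)nc(OCC(F)(F)F)n2)cc1` differs from compound 1 in one place: 2-acetamidoethyl in place of 4-fluorophenyl on a sulfonyl sulfur. Among the measured compounds shown here, the steps that bear on this are the two exchanges of the 4-fluorophenyl on the sulfonyl sulfur already seen, both within the scatter, so no step beyond the scatter is expected from compound 1 to compound 4 in this assay. The expected step is a number 6 percentage points lower from compound 1 to compound 4 (within the scatter). For compound 4 the estimated value is 93%, with a range from 84% to 99%.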

Compound 4, percent of the compound remaining: 100%
The estimate for compound 4 lay 7 percentage points below the measured number; measured number above the stated range.
By their numbers in this assay, from the lowest: compounds 3, 2, 1 and 4 (each within the scatter of the next).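

The 2-acetamidoethyl chain has no ring, yet in this assay it stands on the sulfonyl sulfur with no step beyond the scatter, either for 4-fluorophenyl (a number 1 percentage points higher from compound 1 to compound 4 (within the scatter)) or for isopropyl (a number 4 percentage points higher from compound 2 to compound 4 (within the scatter)). On the amine nitrogen of the chain, acetyl in place of neopentyl also stays within the scatter (a number 10 percentage points higher from compound 3 to compound 4 (within the scatter)). Nothing measured here explains why these numbers stay so close. Going by these compounds, whether a carboxylic acid at the end of the chain, or a longer chain, would give a similar number in this assay remains open.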